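Saturated amide variants of a CDK8 inhibitor series

A few compounds are considered here, and "the series" means these few. Any claim that something is new, unique, unknown or untested is made for them only; others in the source may bear on it.

Measured compounds:
compound 1, `CNC(=O)/C=C/c1ccncc1-c1ccc2ccccc2c1`: 12.4 nM
compound 2, `NNC(=O)COc1ccncc1-c1ccc2ccccc2c1`: "not determined" (no result reported)
compound 3, `O=C(CCc1ccncc1-c1ccc2ccccc2c1)N1CCOCC1`: 45.5 nM

In an assay on a protein complex for inhibition of CDK8/Cyclin C (Homo sapiens), with a stated time of 1 h (a lower number here means a stronger inhibitor, a higher number a weaker inhibitor), compound 1 gives 12.4 nM and compound 3 gives 45.5 nM, so compound 3 carries the highest number of the two that were obtained, a gap beyond the scatter of this assay. Compound 2 has no result in this assay, so nothing can be said of it.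

The next compound, compound 4, `CNC(=O)CCc1ccncc1-c1ccc2ccccc2c1`, keeps the saturated chain of compound 3 and changes the amide: methylamino in place of morpholin-4-yl on a carbonyl carbon. The group that enters is the same methylcarbamoyl terminus found in compound 1, which differs from compound 4 only in having the unsaturated chain.

Because compound 1 gives 12.4 nM with that terminus, while compound 3 gives 45.5 nM with the morpholine, compound 4 is expected to move toward the lower number, with the step from compound 3 to compound 4 estimated as a 2.3-fold lower number from compound 3 to compound 4 (0.36 log units; beyond the scatter) in this assay, beyond the scatter. Compound 4 is thus expected to give about 20 nM in this assay, estimated within 8 nM to 50 nM.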

Compound 4, half-maximal inhibitory concentration: 21.1 nM
For compound 4 the middle estimate is 1.1-fold (0.02 log units) below the measured one; the range from low to high includes it.
By their numbers in this assay, from the lowest: compounds 1 and 4 (each within the scatter of the next); then compound 3.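

Methylamino in place of morpholin-4-yl on a carbonyl carbon gives a 2.2-fold lower number from compound 3 to compound 4 (0.33 log units; beyond the scatter) in this assay, a modest step and the first reading of this position with the saturated chain held constant. A six-membered ring carrying no hydrogen-bond donor leaves, and a group of two heavy atoms with one hydrogen-bond donor enters, so the morpholine amide is not needed to keep a number of this order. With the methylcarbamoyl terminus held, the change from 2-(methylcarbamoyl)ethenyl to 2-(methylcarbamoyl)ethyl gives a 1.7-fold higher number from compound 1 to compound 4 (0.23 log units; within the scatter), which lies within the scatter, so these two chains cannot be told apart in this assay, and no supporting data are at hand to account for either step.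

The compounds shown leave open whether the step from morpholin-4-yl follows the loss of the ring or the arrival of the amide hydrogen, a question that a dimethylamino or a piperidin-1-yl group on the same carbonyl carbon would address. They also leave open how a carboxylic acid or a longer chain in this place would read.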